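Nitrooxy series: the step to compound 3

This account rests on a few compounds, and the source may have more. Where it says the series, first, only, none or still open, it means among the compounds named here.

Measured so far in a functional assay on A549 cells (Homo sapiens) for cytotoxicity, read by resazurin assay, with a stated time of 72 h; on this read-out lower numbers stand for stronger inhibition and higher numbers for weaker inhibition
- compound 1 `COc1cc(/C=C/C(=O)OCCCO[N+](=O)[O-])ccc1OCCCO[N+](=O)[O-]` gives 15800 nM
- compound 2 `COc1cc(/C=C/C(=O)OCCCO[N+](=O)[O-])ccc1O` gives 13200 nM

Among the compounds with values here, compound 2 stands within the scatter of compound 1, the only other measured compound, so the two values cannot be told apart. Compound 3 `COc1cc(/C=C/C(=O)OC/C=C/CO[N+](=O)[O-])ccc1O` differs from compound 2 by a group of 7 heavy atoms (3 carbon, 1 nitrogen, 3 oxygen; no ring) in place of a group of 6 heavy atoms (2 carbon, 1 nitrogen, 3 oxygen; no ring), on a saturated chain carbon bound to an oxygen next to a carbonyl group. The entering group has 2 double bonds outside aromatic rings, the leaving 2-(nitrooxy)ethyl has 1. Within the data shown here, only one measured step exists, a 1.2-fold lower number from compound 1 to compound 2 (0.08 log units; within the scatter). It concerns a 3-(nitrooxy)propyl on an oxygen on an aromatic ring, a different place, so it bears only indirectly. Among the measured compounds shown here, no measurement yet covers the place of this change. In this assay the expected outcome is therefore no step beyond the scatter, with an estimated 1.2-fold lower number from compound 2 to compound 3 (0.08 log units; within the scatter). Compound 3 is estimated at 11000 nM, with an expected range of 4500 nM to 25000 nM.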

Compound 3, half-maximal inhibitory concentration: 5950 nM
Estimate against measurement, compound 3: 1.8-fold (0.27 log units) above; the measured number falls inside the stated range.
By their numbers in this assay, from the lowest: compound 3; then compounds 2 and 1 (each within the scatter of the next).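

In this assay, the place on a saturated chain carbon bound to an oxygen next to a carbonyl group now has its first measured step: the entering group, with 2 double bonds outside aromatic rings, in place of 2-(nitrooxy)ethyl gives a 2.2-fold lower number from compound 2 to compound 3 (0.35 log units; beyond the scatter). Within the data shown here, this place thus shows a modest response beyond the scatter, whereas the only earlier step, a 1.2-fold lower number from compound 1 to compound 2 (0.08 log units; within the scatter), concerned a 3-(nitrooxy)propyl on an oxygen on an aromatic ring and stayed within it. No supporting data on the origin of this step are available.

The change adds a carbon and a double bond together, so the compounds shown cannot separate the two. A saturated 4-(nitrooxy)butyl at this place would test the chain alone, and a plain butyl would test whether the nitrooxy group matters at all.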